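Swapping the Triazole Substituent in a Butenolide Series

The compounds below may be only part of what the source reports. "The series", "measured", "known", "first", "only" and "open" are said of these compounds alone.

Compound 1 `Cc1ccc(S(=O)(=O)NCc2cn(C[C@H](O)[C@H]3OC(=O)C(OCc4ccccc4)=C3OCc3ccccc3)nn2)cc1` gives 16800 nM in a functional assay on A549 cells (Homo sapiens) for antiproliferative activity, read by MTT assay, with a stated time of 72 h; a higher number here means a weaker inhibitor, a lower number a stronger inhibitor.
Compound 2 `O=C1O/C(=C\Cn2cc(-c3cccc(O)c3)nn2)C(OCc2ccccc2)=C1OCc1ccccc1` gives 23300 nM in this assay.
Compound 3 `CCCCCc1ccc(-c2cn(C/C=C3\OC(=O)C(OCc4ccccc4)=C3OCc3ccccc3)nn2)cc1` reaches only the limit > 100000 nM in this assay.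

Among the two numbers measured, compound 1 stands lowest, but compound 2 sits within the scatter of it, so the two cannot be ordered. The third value for compound 3 is a limit of the assay (the limit of > 100000 nM in this assay, at which 1 of the 3 values shown sits).

Compound 4 `O=C1O[C@H]([C@@H](O)Cn2cc(CCCCl)nn2)C(OCc2ccccc2)=C1OCc1ccccc1` has not yet been measured in this assay. It differs from compound 1 in one place: 2-chloroethyl in place of ((4-methylphenyl)sulfonyl)amino on a saturated chain carbon bound to an aromatic carbon. Going by the values given here, the only measured step that also alters the group carried on the triazole ring is an at least 4.2-fold higher number from compound 2 to compound 3 (0.63 log units; beyond the scatter), where a larger aryl group in place of a smaller one pushed the value to the limit. That step points in neither direction cleanly for a change from a sulfonamide-bearing arm to a short chloroalkyl chain, so the account expects a step of a 1.8-fold higher number from compound 1 to compound 4 (0.25 log units; within the scatter), likely weakening but possibly within the scatter. Compound 4 is therefore estimated at 30000 nM, with a range from 9000 nM to 100000 nM.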

Compound 4, half-maximal inhibitory concentration: 29000 nM
The estimate for compound 4 lay 1.0-fold (0.01 log units) above the measured number, and the stated range covers the measured number.
By their numbers in this assay, from the lowest: compounds 1, 2 and 4 (each within the scatter of the next). At a limit, above all of these: compound 3.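

Replacing ((4-methylphenyl)sulfonyl)amino with 2-chloroethyl removes a six-membered aromatic ring, a hydrogen-bond donor and two hydrogen-bond acceptors from this arm, yet in this assay the result is only a 1.7-fold higher number from compound 1 to compound 4 (0.24 log units; within the scatter). The one earlier step in the group carried on the triazole ring, an at least 4.2-fold higher number from compound 2 to compound 3 (0.63 log units; beyond the scatter), lies beyond the scatter and exchanges one aryl group for another, so this is the first step shown in which a group with no ring enters at this substituent. Nothing measured here bears on why so large a change in the group gives a step within the scatter.

The compounds shown leave open whether an amine, a carboxylic acid or a longer chain at this place would also stay within the scatter of compound 1. They also leave open whether a propyl chain without its chlorine would do the same.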